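The source may report more compounds than this note shows. Statements on the series, on what has been measured and on what is new or still open speak of the compounds shown alone.

Of the compounds shown here, two that share a core have been tested in a functional assay on Caco-2 cells (Homo sapiens) for inhibition, read by MTT assay, with a stated time of 48 h, tested at 10 uM; on this read-out lower numbers stand for less inhibition of growth and higher numbers for more inhibition of growth at the one concentration tested. Compound 1, `Cc1cc(=O)c2c(O)c(CN3CCCC3)c(O)c([C@H]3CCN(C)C[C@H]3O)c2o1`, gives 22%. Compound 2, `Cc1oc2c([C@H]3CCN(C)C[C@H]3O)c(O)cc(O)c2c(=O)c1C(O)c1ccc(Cl)cc1`, gives 3%, the lower of the two numbers, and its gap from compound 1 lies beyond the usual scatter of such measurements, so among the measured compounds it stands at the bottom. Compound 3, `Cc1oc2c([C@H]3CCN(C)C[C@H]3O)c(O)cc(O)c2c(=O)c1C(O)c1ccc(F)cc1`, has not yet been measured. It differs from compound 2 in one place: fluoro in place of chloro on an aromatic carbon. Going by the values given here, no measured pair shows what this exchange does here, so its effect is open. The exchange is a small one, and because compound 2 already gives a low number at 3%, the expected step is a number 2 percentage points higher from compound 2 to compound 3 (within the scatter), that is, none beyond the scatter in either direction. Compound 3 is therefore estimated at 5%, with a range from -5% to 18%.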

Compound 3, percent growth inhibition at one concentration: 11%
Compound 3: middle estimate off by 6 percentage points, on the low side, within the range that was stated.
By their numbers in this assay, from the lowest: compounds 2 and 3 (each within the scatter of the next); then compound 1.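

In this assay, going by these compounds alone, this pair gives the first direct look at the place on the aromatic ring para to a large group, and the exchange of chloro for fluoro comes out as a number 8 percentage points higher from compound 2 to compound 3 (within the scatter). The two halogens therefore cannot be told apart on this read-out, so at this place, a change of this one atom does not separate the 4-chlorophenyl from the 4-fluorophenyl compound. No measurement of any property of these two groups is at hand to bear on this result.

Still open, on these data alone, is whether a group of another kind at the same place, such as methoxy or an amine, would shift the number beyond the scatter. A single pair also cannot show whether the same exchange would behave alike on a different core.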